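Methyl for Fluoro on Two Aryl Ether Cores

The source may hold more compounds than are shown below. What is called first, only, known or untested is meant among the compounds shown, and "the series" means these compounds.

Measured so far in an assay on isolated protein for inhibition of Amine oxidase [flavin-containing] B (Homo sapiens), read by Amplex Red, with a stated time of 15 min; a lower number here means a stronger inhibitor, a higher number a weaker inhibitor:
compound 1 `CC(=O)c1ccc(OCc2ccccc2C)cc1` gives 77.1 nM
compound 2 `CC(=O)c1ccc(OCc2ccccc2F)cc1` gives 56.9 nM
compound 3 `CC(=O)c1cccc(OCc2ccc(F)cc2)c1` gives 86.4 nM

Compound 1 and compound 2 share a core and differ by methyl in place of fluoro on an aromatic carbon; the step is a 1.4-fold higher number from compound 2 to compound 1 (0.13 log units; within the scatter). Compound 3 and compound 2 are built from the same atoms joined differently, and the difference between the two cores is not broken down here. Compound 4 `CC(=O)c1cccc(OCc2ccc(C)cc2)c1` has not yet been measured in this assay. It differs from compound 3 by methyl in place of fluoro on an aromatic carbon, the same kind of change as that from compound 2 to compound 1, though here the place is para to a large group where before it was ortho to a large group. Because the earlier step was a 1.4-fold higher number from compound 2 to compound 1 (0.13 log units; within the scatter), a similarly small step is expected, a 1.2-fold higher number from compound 3 to compound 4 (0.08 log units; within the scatter). Compound 4 is therefore estimated at 105 nM, between 50 nM and 220 nM.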

Compound 4, half-maximal inhibitory concentration: 140 nM
Compound 4: middle estimate off by 1.3-fold (0.12 log units), on the low side, within the range that was stated.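

Methyl in place of fluoro gives a 1.6-fold higher number from compound 3 to compound 4 (0.21 log units; within the scatter) in this assay. Set beside the earlier step, the change shows no detectable difference between the two cores: the same change on two cores in this assay, a 1.4-fold higher number (0.13 log units; within the scatter) from compound 2 to compound 1 and a 1.6-fold higher number (0.21 log units; within the scatter) from compound 3 to compound 4, 1.2-fold (0.08 log units) apart, within the scatter of two such steps. Among the compounds shown here, since each step lies within the scatter, the pair shows only that this change stayed small on these two cores; it does not show a real effect of the change on either core, nor that the two places are equivalent, nor that the step would stay small on another core.

The compounds shown leave open whether a different group in that place, such as chloro, a nitrile or an amine, would shift the number beyond the scatter. They also leave open what a carboxylic acid would do in place of the carbonyl-bearing group.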